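Aryl swap at the fused-ring nitrogen: compound 3 to compound 4

A few compounds are considered here, and "the series" means these few. Any claim that something is new, unique, unknown or untested is made for them only; others in the source may bear on it.

Measured so far:
compound 1 `CC(C)(C)COC(=O)N1CCC(Oc2ncnc3c2CCN3c2ccc(S(C)(=O)=O)cc2F)CC1` — 39.8 nM
compound 2 `CC(C)OC(=O)N1CCC(Sc2ncnc3c2CCN3c2ccc(S(C)(=O)=O)cc2F)CC1` — 79.4 nM
compound 3 `CC(C)OC(=O)N1CCC(Oc2ncnc3c2CCN3c2ccc(S(C)(=O)=O)cn2)CC1` — 126 nM

In a functional assay on CHO-K1 cells for agonist activity at Glucose-dependent insulinotropic receptor (Homo sapiens), read by a luciferase reporter, with a stated time of 5 h (on this read-out lower numbers stand for an effect already at smaller amounts and higher numbers for an effect only at larger amounts of compound), compound 3 gives the highest of the three numbers. Against compound 2 the gap lies within the scatter; against compound 1 it lies beyond it, compound 1 showing the lower number. Neither pair differs in one place only, so no single step can be read from them.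

Compound 4 `CC(C)OC(=O)N1CCC(Oc2ncnc3c2CCN3c2ccc(S(C)(=O)=O)c(F)c2)CC1` carries 3-fluoro-4-(methylsulfonyl)phenyl in place of 5-(methylsulfonyl)pyridin-2-yl on a nitrogen on an aromatic ring in a ring. Compounds 1 and 2, which bear a fluorophenyl rather than a pyridyl at this position, show lower numbers than compound 3 in this assay, though their fluorine sits elsewhere on the ring. A modest step downward is therefore expected, a 2.0-fold lower number from compound 3 to compound 4 (0.30 log units; within the scatter), though it may not clear the scatter. Compound 4 is estimated at 63 nM, within 20 nM to 200 nM.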

Compound 4, half-maximal effective concentration: 158 nM
Compound 4: middle estimate off by 2.5-fold (0.40 log units), on the low side; low and high end bracket the measured number.
By their numbers in this assay, from the lowest: compounds 1, 2, 3 and 4 (each within the scatter of the next, the first and the last beyond it).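

In this assay, going by these compounds alone, 3-fluoro-4-(methylsulfonyl)phenyl in place of 5-(methylsulfonyl)pyridin-2-yl on a nitrogen on an aromatic ring in a ring gives a 1.3-fold higher number from compound 3 to compound 4 (0.10 log units; within the scatter), the first single-place comparison. At this position, the two aryl groups cannot be told apart on this read-out, so the exchange of the ring nitrogen for a fluorinated carbon ring shows no resolved effect. No supporting data bear on the reason for this outcome. Open, going by these compounds, is whether a nitrile or a carboxylic acid in place of the methylsulfonyl group would shift the number beyond the scatter. Also open, on these data alone, is whether the two aryl groups stay level with a different rest of the molecule.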